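Aryl-swap at the benzylidene position: series notes

This account rests on a few compounds, and the source may have more. Where it says the series, first, only, none or still open, it means among the compounds named here.

Measured so far in a functional assay on HeLa cells (Homo sapiens) for cytotoxicity, read by CCK-8 assay, with a stated time of 72 h; on this read-out higher numbers stand for weaker inhibition and lower numbers for stronger inhibition:
compound 1 `C=CCn1c(=O)/c(=C\c2ccc(Cl)c(Cl)c2)[nH]c(=O)/c1=C\c1ccccc1`: "not active" (no number reported)
compound 2 `C=CCn1c(=O)/c(=C\c2cc(F)ccc2C)[nH]c(=O)/c1=C\c1ccccc1OC`: 2900 nM
compound 3 `C=CCn1c(=O)/c(=C\c2cccc(Br)c2)[nH]c(=O)/c1=C\c1cccc(Br)c1`: "not active" (no number reported)

Compound 2 holds the only numerical read-out in this assay; compound 1 and compound 3, each carrying two halogenated aryl groups on the shared core, are recorded without a number. Going by the values given here, no step between two measured compounds with a single change is available, so no computed step can be stated.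

The next compound, compound 4 `C=CCn1c(=O)/c(=C\c2ccccc2F)[nH]c(=O)/c1=C\c1ccccc1OC`, keeps the 2-methoxyphenyl side of compound 2 and alters the other aryl group: 2-fluorophenyl in place of 5-fluoro-2-methylphenyl on a double-bonded chain carbon bound to an aromatic carbon. Among the compounds with values here, nothing in the measured set shows what this change does; the only guidance is that compound 2 gives a number while the other two do not. The step from compound 2 to compound 4 is expected to be small and toward weaker inhibition, a 1.7-fold higher number from compound 2 to compound 4 (0.24 log units; within the scatter), with a fair chance that the read-out again comes back without a number. Compound 4 is therefore estimated at 5000 nM, in the range 1500 nM to 20000 nM.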

Compound 4, half-maximal inhibitory concentration: 45000 nM
Compound 4: the middle estimate sits 9.0-fold (0.95 log units) below what was measured; measured number above the stated range.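

With 2-fluorophenyl in place of 5-fluoro-2-methylphenyl on a double-bonded chain carbon bound to an aromatic carbon, the read-out in this assay shifts markedly, with a 16-fold higher number from compound 2 to compound 4 (1.19 log units; beyond the scatter). This first readable step shows that, with the 2-methoxyphenyl side held fixed, the read-out responds strongly to the substitution on this aryl group, even though compound 4 still returns a number, unlike compound 1 and compound 3. No measurement on hand accounts for the size of this step.

The two aryl groups differ both in the methyl group and in where the fluorine sits, so the contribution of each change remains unresolved. Also open, from the compounds shown here alone, is how this position would respond to an aryl group carrying an amine or a carboxylic acid.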